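Exchanging the Terminal Ring of the Side Chain

The source may hold more compounds than are shown below. What is called first, only, known or untested is meant among the compounds shown, and "the series" means these compounds.

Of the compounds shown here, two from this series have been measured in a functional assay on HT-29 cells (Homo sapiens) for inhibition, read by MTT assay, with a stated time of 72 h; a higher number here means a weaker inhibitor, a lower number a stronger inhibitor. Compound 1 `COc1cc2c(Oc3ccc(NC(=O)c4nn(-c5ccccc5C)c(=O)cc4C)cc3F)ccnc2cc1OCCCN1CCN(C)CC1` gives 3790 nM. Compound 2 `COc1ccc(-n2nc(C(=O)Nc3ccc(Oc4ccnc5cc(OCCCN6CCCCC6)c(OC)cc45)c(F)c3)c(C)cc2=O)cc1` gives 3200 nM; this is the lower of the two numbers, yet the gap to compound 1 lies within the usual scatter, so neither compound can be ranked above the other. Compound 3 `COc1ccc(-n2nc(C(=O)Nc3ccc(Oc4ccnc5cc(OCCCN6CCN(C)CC6)c(OC)cc45)c(F)c3)c(C)cc2=O)cc1` has not yet been measured. It differs from compound 2 in one place: 4-methylpiperazin-1-yl in place of piperidin-1-yl on a saturated chain carbon, three bonds along the chain from an oxygen on an aromatic ring. Going by the values given here, no pair of measured compounds isolates this change, so its effect has to be inferred. Compound 1 already carries the entering group, though it differs from compound 3 elsewhere. The value of compound 1, 3790 nM, sits within the scatter of compound 2. The step of a 1.1-fold higher number from compound 2 to compound 3 (0.04 log units; within the scatter) is therefore expected to stay within the scatter, with no clear direction. Compound 3 is expected to give 3500 nM, with a range from 1500 nM to 8000 nM.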

Compound 3, half-maximal inhibitory concentration: 3520 nM
Estimate against measurement, compound 3: 1.0-fold (0.00 log units) below, and the stated range covers the measured number.
By their numbers in this assay, from the lowest: compounds 2, 3 and 1 (each within the scatter of the next).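

The exchange of piperidin-1-yl for 4-methylpiperazin-1-yl now has a direct reading in this assay (a 1.1-fold higher number from compound 2 to compound 3 (0.04 log units; within the scatter)), so at this saturated chain carbon, three bonds along the chain from an oxygen on an aromatic ring, the two terminal rings cannot be told apart. Compound 3 also isolates a second change, 4-methoxyphenyl in place of 2-methylphenyl on an aromatic nitrogen (a 1.1-fold lower number from compound 1 to compound 3 (0.03 log units; within the scatter)), and this exchange likewise stays within the scatter. Nothing available bears on the reason for either result.

From the compounds shown here alone, whether morpholin-4-yl, an open-chain dimethylamino group or a terminal carboxylic acid would also stay within the scatter remains open. So does the effect of a shorter or longer chain in place of 3-(4-methylpiperazin-1-yl)propyl.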